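This account rests on a few compounds, and the source may have more. Where it says the series, first, only, none or still open, it means among the compounds named here.

Measured so far in an ADME assay on PA-1 cells (Homo sapiens) for cytotoxicity, read by MTT assay, with a stated time of 72 h; on this read-out lower numbers stand for stronger inhibition and higher numbers for weaker inhibition:
Compound 1 `COc1ccc(C2=C(c3cc(OC)c(OC)c(OC)c3)C(=O)C(OC(C)=O)C2)cc1OC(C)C`: > 100 ug/mL
Compound 2 `COc1ccc(C2=C(c3cc(OC)c(OC)c(OC)c3)C(=O)C(OC(C)=O)C2)cc1`: < 1 ug/mL
Compound 3 `COc1ccc(C2=C(c3cc(OC)c(OC)c(OC)c3)C(=O)C(O)C2)cc1Cl`: > 100 ug/mL

All three readings are limits of the assay, not numbers. For compound 3 the reading is a limit, > 100 ug/mL. Compound 4 `COc1ccc(C2=C(c3cc(OC)c(OC)c(OC)c3)C(=O)C(OC(C)=O)C2)cc1Cl` turns hydroxy into acetoxy: acetyl in place of hydrogen on an oxygen on a saturated carbon. For the measured compounds named here, no measured step tests this change directly. Going by the values given here, the one measured step, an at least 100-fold lower number from compound 1 to compound 2 (2.00 log units; beyond the scatter), swaps isopropoxy for hydrogen on an aromatic carbon. It is large, and both of its compounds carry the acetoxy of compound 4, so acetoxy alone does not settle the outcome. A step towards a lower number in this assay is expected, with its size uncertain. The expected change is an at least 10-fold lower number from compound 3 to compound 4 (1.00 log units; beyond the scatter). For compound 4 the estimate is 10 ug/mL, with an expected range from 1 ug/mL to 100 ug/mL.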

Compound 4, half-maximal inhibitory concentration: > 100 ug/mL
Compound 4: a limit, no number (the forecaster's own chance of this, stated with the estimate: 40%); middle value at least 10-fold (1.00 log units) from the limit.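

In this assay, chloro in place of hydrogen on an aromatic carbon gives an at least 100-fold higher number from compound 2 to compound 4 (2.00 log units; beyond the scatter), so acetoxy does not keep the number low here. Compound 4 gives > 100 ug/mL, a limit of the assay. Among the three acetoxy compounds, only compound 2, with hydrogen on that carbon, reads low, while the steps to compound 4 from compound 3 and compound 1 cannot be read.

On these data alone, whether fluoro, methyl or an amine on that carbon would give a low reading stays open. So does how far compound 4 lies past its limit.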